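Liver microsome stability: aryl ether linker variants

The source may hold more compounds than are shown below. What is called first, only, known or untested is meant among the compounds shown, and "the series" means these compounds.

Measured compounds in an ADME assay on microsomes from liver (Rattus norvegicus) for metabolic stability, with a stated time of 10 min; a higher number here means that more of the compound is left, a lower number that less of the compound is left:
- compound 1, `COc1cc(OCc2cccc(COc3ccccc3)c2)c2cc(-c3cn4nc(OC)sc4n3)oc2c1`: 64%
- compound 2, `COc1cc(OCc2cccc(CCc3ccccc3)c2)c2cc(-c3cn4nc(OC)sc4n3)oc2c1`: 68%
- compound 3, `COc1cc(OCc2cccc(Oc3ccccc3)c2)c2cc(-c3cn4nc(OC)sc4n3)oc2c1`: 42%

Compound 3 stands lowest of the three in this assay. Compound 1 and compound 2 sit close to each other, as the step of a number 4 percentage points higher from compound 1 to compound 2 (within the scatter) is within the scatter. From both, the step to compound 3 is a fall beyond the scatter: a number 22 percentage points lower from compound 1 to compound 3 (beyond the scatter) and a number 26 percentage points lower from compound 2 to compound 3 (beyond the scatter).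

Compound 4, `COc1cc(OCc2cccc(OCc3ccccc3)c2)c2cc(-c3cn4nc(OC)sc4n3)oc2c1`, has not yet been measured. Its change from compound 3 is benzyl in place of phenyl on an oxygen on an aromatic ring, that is, phenoxy to benzyloxy. The two steps that bear on it, from compound 1 and from compound 2 to compound 3, each remove a one-carbon or two-carbon link between the two outer rings, and both lower the number by a modest amount. Compound 4 restores such a link, on the other side of the oxygen, so the reverse direction is expected, of roughly the size seen in those two steps. Compound 4 is therefore expected to give about 60% in this assay, within 46% to 74%, corresponding to an expected step of a number 18 percentage points higher from compound 3 to compound 4 (beyond the scatter).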

Compound 4, percent of the compound remaining: 76%
Compound 4: middle estimate off by 16 percentage points, on the low side, and the stated range ends below it.
By their numbers in this assay, from the lowest: compound 3; then compounds 1, 2 and 4 (each within the scatter of the next, the first and the last beyond it).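

In this assay, the group on the oxygen on the aromatic ring proves decisive: benzyl in place of phenyl gives a number 34 percentage points higher from compound 3 to compound 4 (beyond the scatter), so the drop seen with phenoxy does not extend to benzyloxy. The earlier compounds shown here did not show that the placement of the oxygen within the link can matter, yet benzyloxy in place of phenoxymethyl gives a number 12 percentage points higher from compound 1 to compound 4 (beyond the scatter). Benzyloxy in place of phenethyl gives a number 8 percentage points higher from compound 2 to compound 4 (within the scatter), so these two groups cannot be told apart in this read-out.

Nothing available explains these steps or identifies what happens to the compounds in the microsomes. Also open, going by these compounds, is whether a longer chain on the same oxygen, such as phenethyl or phenylpropyl, or an amine in place of that oxygen would keep the number of compound 4.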